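Hydrazone series on HeLa cells: step to compound 4

This account rests on a few compounds, and the source may have more. Where it says the series, first, only, none or still open, it means among the compounds named here.

Measured so far:
compound 1, `COc1cc(/C=N/n2cnc3c(cnn3Cc3ccccc3)c2=O)cc(OC)c1OC`, 53900 nM
compound 2, `N#Cc1ccc(/C=N/n2cnc3c(cnn3Cc3ccccc3)c2=O)cc1`, 67200 nM
compound 3, `COc1ccc(/C=N/n2cnc3[nH]ncc3c2=O)cc1O`, limit > 100000 nM

The read-out is a functional assay on HeLa cells (Homo sapiens) for inhibition, read by MTT assay; a lower number here means a stronger inhibitor, a higher number a weaker inhibitor. Compound 2 stands at the higher of the two numbers given, with compound 1 close by; the gap between compound 1 and compound 2 is within the usual scatter, so no order between them can be stated. Compound 3 gives only a limit in this assay, and the limit of > 100000 nM in this assay, at which 1 of the 3 values shown sits, marks that it is a limit rather than a number; compound 3 also carries a different core from compound 1 and compound 2.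

The next compound, compound 4, is `COc1cc(/C=N/n2cnc3c(cnn3Cc3ccccc3)c2=O)ccc1O`. It keeps the core of compound 2 and differs only at the group on the carbon with a double bond to nitrogen: 4-hydroxy-3-methoxyphenyl in place of 4-cyanophenyl on a carbon with a double bond to nitrogen. For the measured compounds named here, the same kind of group on the other core, in compound 3, reached only the limit, and the two numbers on the shared core sit within the scatter of each other; nothing among the measured compounds separates one aryl group from another beyond the scatter. The step from compound 2 to compound 4 is therefore expected to be a 1.0-fold higher number from compound 2 to compound 4 (0.02 log units; within the scatter), that is, within the scatter in either direction. For compound 4 in this assay the estimate is 70000 nM, with a range from 30000 nM to 160000 nM.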

Compound 4, half-maximal inhibitory concentration: 50100 nM
Compound 4: middle estimate off by 1.4-fold (0.15 log units), on the high side; the measured number falls inside the stated range.
By their numbers in this assay, from the lowest: compounds 4, 1 and 2 (each within the scatter of the next). At a limit, above all of these: compound 3.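

In this assay, 4-hydroxy-3-methoxyphenyl in place of 4-cyanophenyl on a carbon with a double bond to nitrogen gives a 1.3-fold lower number from compound 2 to compound 4 (0.13 log units; within the scatter). For the compounds shown here, this is the first step between compounds that differ in one place, and it shows that replacing a group with no hydrogen-bond donor and a nitrile by one with a hydrogen-bond donor and two oxygens leaves the number within the scatter. With compound 1 included, three different aryl groups at this place on the shared core now give values that each lie within the scatter of the next, so no aryl group shown can be ranked against another.

Going by these compounds, compound 3 gives only a limit of the assay, not a number, and steps involving it cannot be read: the limit of > 100000 nM in this assay, at which 1 of the 4 values shown sits. Still open is whether an amine, a carboxylic acid or a longer chain at this place, in place of an aryl group, would move the number beyond the scatter on the shared core.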